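This account rests on a few compounds, and the source may have more. Where it says the series, first, only, none or still open, it means among the compounds named here.

Compound 1, `Oc1cccc(-c2cc(-c3cccc(Cl)c3)nc(-c3ccccn3)c2)c1`, gives "not determined" (no result reported) in a functional assay on DU-145 cells (Homo sapiens) for cytotoxicity, read by CCK-8 assay and cell counting, with a stated time of 2 days; on this read-out higher numbers stand for weaker inhibition and lower numbers for stronger inhibition.
Compound 2, `Oc1cccc(-c2cc(-c3ccccc3)nc(-c3ccccc3Cl)c2)c1`, gives 1480 nM.
Compound 3, `Oc1cccc(-c2cc(-c3cccc(Cl)c3)nc(-c3ccco3)c2)c1`, gives 2020 nM.

All three compounds share the same core carrying a 3-hydroxyphenyl group, and differ in the two other groups attached to it. Only two of them come with a number. Compound 3 has the higher of those two numbers, but the gap to compound 2 is within the usual scatter of repeated measurements, so the two cannot be placed in any order on this basis; compound 1 contributes no number at all.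

Compound 4, `Oc1cccc(-c2cc(-c3ccccc3)nc(-c3cccc(Cl)c3)c2)c1`, is reached from compound 3 by a single change: phenyl in place of furan-2-yl on an aromatic carbon. Among the compounds with values here, no pair of measured compounds differs in just one place, so there is no measured step to copy for the size of this change.

The expectation is therefore cautious. Compound 2, which also carries a phenyl group on the core, gives 1480 nM, and compound 3 gives 2020 nM; the gap between these two numbers is within the scatter. Compound 4 is expected to show a step of a 1.3-fold lower number from compound 3 to compound 4 (0.10 log units; within the scatter), that is, no change beyond the scatter. Compound 4 is estimated at 1600 nM, with a range from 600 nM to 4000 nM in this assay.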

Compound 4, half-maximal inhibitory concentration: 2750 nM
For compound 4 the middle estimate is 1.7-fold (0.24 log units) below the measured one, within the range that was stated.
By their numbers in this assay, from the lowest: compounds 2, 3 and 4 (each within the scatter of the next).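

In this assay, within the data shown here, phenyl in place of furan-2-yl on this aromatic carbon next to the ring nitrogen gives a 1.4-fold higher number from compound 3 to compound 4 (0.13 log units; within the scatter), the first measured comparison in which only this group differs. At this place, then, a five-membered aromatic ring with an oxygen and a six-membered aromatic ring of carbon only cannot be told apart, and the same holds for the second one-place exchange, 3-chlorophenyl in place of 2-chlorophenyl, which gives a 1.9-fold higher number from compound 2 to compound 4 (0.27 log units; within the scatter). No measurement shown here explains why either exchange stays within the scatter.

From the compounds shown here alone, both exchanges swap one aromatic ring for another, so it remains open whether something of a different kind at the place next to the ring nitrogen, such as an amine, a carboxylic acid or a longer chain, would shift the number beyond the scatter. All the compounds shown also carry the 3-hydroxyphenyl group, which leaves open what would happen with a methoxy group in place of its hydroxyl.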